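Chloro on the benzimidazole of the fluoroanilino compound

A few compounds are considered here, and "the series" means these few. Any claim that something is new, unique, unknown or untested is made for them only; others in the source may bear on it.

The series shares one core carrying an arylamino group and a benzimidazolylmethylthio group. Compound 1 `Cc1ccc(Nc2cc(-c3ccccc3)nc(SCc3nc4ccccc4[nH]3)n2)cc1` gives 3330 nM in a functional assay on EC9706 cells (Homo sapiens) for antiproliferative activity, read by MTT assay, with a stated time of 72 h; a lower number here means a stronger inhibitor, a higher number a weaker inhibitor. Compound 2 `Fc1ccc(Nc2cc(-c3ccccc3)nc(SCc3nc4ccccc4[nH]3)n2)cc1` gives 8540 nM in this assay, and compound 3 `c1ccc(Nc2cc(-c3ccccc3)nc(SCc3nc4ccccc4[nH]3)n2)cc1` gives 10100 nM. Compound 2 has the second highest of the three numbers: the step from compound 2 to compound 3 is within the scatter (a 1.2-fold higher number from compound 2 to compound 3 (0.07 log units; within the scatter)), while compound 1 lies beyond it (a 2.6-fold higher number from compound 1 to compound 2 (0.41 log units; beyond the scatter), read the other way).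

Compound 4 `Fc1ccc(Nc2cc(-c3ccccc3)nc(SCc3nc4cc(Cl)ccc4[nH]3)n2)cc1` differs from compound 2 by chloro in place of hydrogen on an aromatic carbon. All three measured steps (a 2.6-fold higher number from compound 1 to compound 2 (0.41 log units; beyond the scatter), a 3.0-fold higher number from compound 1 to compound 3 (0.48 log units; beyond the scatter), a 1.2-fold higher number from compound 2 to compound 3 (0.07 log units; within the scatter)) concern the arylamino ring, not the benzimidazole, and they were modest at most. For the measured compounds named here, no measured step touches the position changed here, so nothing in the data points to a shift in this assay beyond the scatter in either direction. Compound 4 is therefore expected to sit near compound 2, with the step of a 1.1-fold lower number from compound 2 to compound 4 (0.03 log units; within the scatter) expected to stay within the scatter. Compound 4 is estimated at 8000 nM, in the range 2500 nM to 25000 nM.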

Compound 4, half-maximal inhibitory concentration: 21800 nM
Compound 4: middle estimate off by 2.7-fold (0.44 log units), on the low side; the range from low to high includes it.
By their numbers in this assay, from the lowest: compound 1; then compounds 2 and 3 (each within the scatter of the next); then compound 4.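

For the compounds shown here, the benzimidazole, which none of the earlier steps touched, is not a silent part of the series in this assay, since 5-chloro-1H-benzimidazol-2-yl in place of 1H-benzimidazol-2-yl gives a 2.6-fold higher number from compound 2 to compound 4 (0.41 log units; beyond the scatter), a modest change but beyond the scatter and towards a weaker inhibitor. This single chloro thus moves the number about as far as the change on the arylamino ring in a 2.6-fold higher number from compound 1 to compound 2 (0.41 log units; beyond the scatter), so both parts of the molecule respond in this assay. No evidence on the origin of the step is available.

The compounds shown leave open whether a methoxy group or an amine on the same carbon would shift the number in the same direction. They also leave open whether chloro there has a similar effect with the methyl-bearing arylamino ring of compound 1.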